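This account rests on a few compounds, and the source may have more. Where it says the series, first, only, none or still open, it means among the compounds named here.

Working notes on a short series of tetradecylamides of threonine tested for cytotoxicity in a functional assay on SiHa cells (Homo sapiens) for cytotoxicity, read by MTT assay, with a stated time of 48 h; on this read-out higher numbers stand for weaker inhibition and lower numbers for stronger inhibition.

Compound 1 `CCCCCCCCCCCCCCNC(=O)[C@@H](N)[C@@H](C)O` carries a free amine; in this assay compound 1 gives 11000 nM. Compound 2 `CCCCCCCCCCCCCCNC(=O)[C@@H](NC(=O)c1nccc2ccccc12)[C@@H](C)O` carries an isoquinoline-1-carboxamide on that nitrogen; in this assay compound 2 gives 21600 nM. Among the measured compounds shown here, of the two numbers measured so far, that of compound 2 is the highest, the only neighbour being compound 1, and the gap between the two lies within the scatter, so no real difference between them is claimed.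

Compound 3 `CCCCCCCCCCCCCCNC(=O)[C@@H](NC(=O)/C=C/c1ccccc1)[C@@H](C)O` is not yet measured. Its change from compound 2 is 2-phenylethenyl in place of isoquinolin-1-yl on a carbonyl carbon. For the measured compounds named here, no step between measured compounds is available to guide this change. Going by the values given here, the one comparison in hand, compound 1 against compound 2, shows that a large change at the amide nitrogen left the value within the scatter, so for compound 3 the expected step of a 1.4-fold lower number from compound 2 to compound 3 (0.16 log units; within the scatter) is none beyond the scatter, in no preferred direction. Compound 3 is therefore expected to give about 15000 nM, with a range from 6000 nM to 40000 nM.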

Compound 3, half-maximal inhibitory concentration: 35800 nM
Estimate against measurement, compound 3: 2.4-fold (0.38 log units) below; the range from low to high includes it.
By their numbers in this assay, from the lowest: compounds 1, 2 and 3 (each within the scatter of the next, the first and the last beyond it).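

In this assay, the exchange of isoquinolin-1-yl for 2-phenylethenyl on the carbonyl carbon gives a 1.7-fold higher number from compound 2 to compound 3 (0.22 log units; within the scatter) and so does not separate the two groups at this position, although the aromatic ring with a hetero atom leaves and a double bond outside aromatic rings enters. Substitution on the amine nitrogen now yields its first step beyond the scatter, with (2-phenylethenyl)carbonyl in place of hydrogen giving a 3.3-fold higher number from compound 1 to compound 3 (0.51 log units; beyond the scatter) as a modest loss of inhibition, but this holds for compound 3 alone, since compound 1 at 11000 nM and compound 2 at 21600 nM remain within the scatter of each other. No measurement in hand bears on the reason for these values.

Still open, on these data alone, is whether the double bond matters at this carbonyl carbon, which a saturated 2-phenylethyl group or a plain phenyl group in the same place would help to settle. Also open, as far as these compounds go, is how far these values depend on the tetradecyl chain, a question that a shorter chain such as decyl on the same amide nitrogen would address.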